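Swapping a pyridinylmethyl for a cyclopentyl on a urea nitrogen

The source may hold more compounds than are shown below. What is called first, only, known or untested is meant among the compounds shown, and "the series" means these compounds.

Measured so far in a functional assay on MCF7 cells (Homo sapiens), read by MTT assay, with a stated time of 72 h; on this read-out higher numbers stand for weaker inhibition and lower numbers for stronger inhibition:
- compound 1, `CCN(CC)C(=O)NCCCC(C)Nc1cc(OC)cc2cccnc12`: > 63000 nM
- compound 2, `COc1cc(NC(C)CCCNC(=O)NCc2ccncc2)c2ncccc2c1`: 30000 nM
- compound 3, `COc1cc(NC(C)CCCNC(=O)N(C2CCCCC2)C2CCCCC2)c2ncccc2c1`: 9000 nM

The value shown for compound 1 is a limit of this assay, not a number. Among the two numbers, compound 2 has the higher one, so it is the weaker inhibitor of the pair; compound 3 sits beyond the scatter on the stronger side.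

Compound 4, `COc1cc(NC(C)CCCNC(=O)NC2CCCC2)c2ncccc2c1`, has not yet been measured. It differs from compound 2 in one place: cyclopentyl in place of (pyridin-4-yl)methyl on an amide-type nitrogen. Among the measured compounds shown here, the only measured step that touches this urea nitrogen is an at least 2.1-fold lower number from compound 1 to compound 2 (0.32 log units; beyond the scatter), which shows that what sits on this nitrogen can move the number beyond the scatter. Compound 3, which also carries only saturated carbon rings on this nitrogen, gives a lower number than compound 2.

Compound 4 is therefore expected to give 15000 nM in this assay, within 6000 nM to 40000 nM, which would be a 2.0-fold lower number from compound 2 to compound 4 (0.30 log units; within the scatter), a modest step toward stronger inhibition.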

Compound 4, half-maximal inhibitory concentration: 30000 nM
Compound 4: middle estimate off by 2.0-fold (0.30 log units), on the low side; measured number inside the range.
By their numbers in this assay, from the lowest: compound 3; then compounds 2 and 4 (each within the scatter of the next). At a limit, above all of these: compound 1.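

In this assay, a (pyridin-4-yl)methyl and a cyclopentyl on this urea nitrogen cannot be told apart, even though one carries an aromatic ring with a hetero atom and the other a ring of carbon only: the swap gives no change at the digits printed from compound 2 to compound 4 (within the scatter). Cyclopentylamino in place of diethylamino gives an at least 2.1-fold lower number from compound 1 to compound 4 (0.32 log units; beyond the scatter), the same printed size as the earlier step to ((pyridin-4-yl)methyl)amino. Compound 1 stands at a limit of the assay, not at a number, so this step has a lower bound but no known size: the limit of > 63000 nM in this assay, at which 1 of the 4 values shown sits.

Going by these compounds, what remains open is whether a different kind of group on this nitrogen, such as a longer chain ending in an amine or a carboxylic acid, would shift the number. A plain phenyl ring is also untested among the compounds shown, so the pair cannot say whether aromatic character alone matters here.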